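The compounds below may be only part of what the source reports. "The series", "measured", "known", "first", "only" and "open" are said of these compounds alone.

Of the compounds shown here, two have been measured so far in an assay on isolated protein for inhibition of aldehyde dehydrogenase 1A1 (Homo sapiens), read by spectrophotometry, tested at 10 uM; on this read-out higher numbers stand for more inhibition at the one concentration tested (going by the name of the read-out) and lower numbers for less inhibition. Compound 1 `Cc1cccc(Cn2c(CN3CCN(C(=O)CC(C)C)CC3)nc3ccccc32)c1` gives 71.4% in this assay. Compound 2 `O=C(C1CC1)N1CCN(Cc2nc3ccccc3n2CC2CC2)CC1` gives 21.2% in this assay. Compound 1 therefore holds the higher of the two numbers, and the gap separating it from compound 2 lies beyond the scatter of repeated measurements. For the measured compounds named here, the two structures differ from each other in more than one place, so no single step between measured compounds can be read from this pair.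

Compound 3 `Cc1cccc(Cn2c(CN3CCN(C(=O)c4ccc(Br)cc4)CC3)nc3ccccc32)c1` has not yet been measured. It differs from compound 1 in one place: 4-bromophenyl in place of isobutyl on a carbonyl carbon. The measured pair gives no guidance on what an aromatic ring in place of a chain at this carbonyl does to the read-out. Compound 1 already stands high. The step of a number 3.6 percentage points higher from compound 1 to compound 3 (within the scatter) is expected to be small, within the scatter, with a slight lean upward. For compound 3 the estimate in this assay is 75%, with a range from 50% to 92%.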

Compound 3, a percentage reported as inhibition, at one concentration (the size of the read-out at that concentration, not a potency): 25.8%
Estimate against measurement, compound 3: 49.2 percentage points above; measured number below the stated range.
By their numbers in this assay, from the lowest: compounds 2 and 3 (each within the scatter of the next); then compound 1.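

In this assay, the group on a carbonyl carbon whose other neighbour is an amide-type nitrogen in a ring proves able to move the number on its own: putting 4-bromophenyl in place of isobutyl gives a number 45.6 percentage points lower from compound 1 to compound 3 (beyond the scatter), with everything else in the structure unchanged. For the compounds shown here, this is the first step between compounds that differ in one place, which the earlier pair could not provide, and it shows that the part shared by compound 1 and compound 3 does not by itself secure a high number. Nothing available explains the size of this step.

The compounds shown leave open whether the loss follows from the aromatic ring itself or from the bromine on it, a question that phenyl without the bromine, or cyclohexyl, on the same carbonyl would help to separate. Also open, from the compounds shown here alone, is how much further the group at this carbonyl can be varied from isobutyl, for instance with a longer chain such as pentyl, or with a chain that ends in an amine or a carboxylic acid.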